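Ether Bulk and Solubility on a Shared Core

The source may hold more compounds than are shown below. What is called first, only, known or untested is meant among the compounds shown, and "the series" means these compounds.

Compound 1 `CCOc1cc(-c2ccnc(N)n2)cc2[nH]nc(N)c12` gives 861000 nM in a physicochemical assay for solubility, read by LC-MS, in phosphate buffer, measured as kinetic solubility, with a stated time of 24 h, at 25 degrees C, at pH 7.4; a higher number here means a more soluble compound, a lower number a less soluble compound.
Compound 2 `CC(C)(C)Oc1cc(-c2ccnc(N)n2)cc2[nH]nc(N)c12` gives 68000 nM in this assay.
Compound 3 `COc1cc(-c2ccnc(N)n2)cc2[nH]nc(N)c12` gives > 100000 nM in this assay, which is a limit of the assay and not a number.

The three measured compounds share one core and differ only in the group on the ether oxygen. Compound 3 carries a methyl there, and for compound 3 only a limit is known (the limit of > 100000 nM in this assay, at which 1 of the 3 values shown sits), so its place among the three can be told only in part. Going from compound 1 to compound 2, a 13-fold lower number from compound 1 to compound 2 (1.10 log units; beyond the scatter). From compound 2 to compound 3, an at least 1.4-fold higher number from compound 2 to compound 3 (0.16 log units; that floor lies within the scatter). The step from compound 1 to compound 3 cannot be read because of that limit of > 100000 nM in this assay, at which 1 of the 3 values shown sits: a step that the limit leaves unreadable from compound 1 to compound 3.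

Compound 4 `Nc1nccc(-c2cc(OC3CCOCC3)c3c(N)n[nH]c3c2)n1` is the next member: oxan-4-yl in place of methyl on an oxygen on an aromatic ring. Among the compounds with values here, the one readable step, tert-butyl in place of ethyl from compound 1 to compound 2, went with a much lower number, and oxan-4-yl in place of methyl is a move in the same direction of size, though with one counted acceptor entering. Since compound 3 sits only above a limit, the starting point itself is uncertain. A downward step is therefore expected, about an at least 1.2-fold lower number from compound 3 to compound 4 (0.09 log units; that floor lies within the scatter). Compound 4 is expected to give roughly 80000 nM, within 15000 nM to 400000 nM.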

Compound 4, solubility: 770000 nM
Compound 4: middle estimate off by 9.6-fold (0.98 log units), on the low side, and the stated range ends below it.
By their numbers in this assay, from the lowest: compound 2; then compounds 4 and 1 (each within the scatter of the next).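

Compound 4 shows that a larger group on this oxygen need not go with a low number in this assay. Oxan-4-yl in place of tert-butyl gives an 11-fold higher number from compound 2 to compound 4 (1.05 log units; beyond the scatter), so among the groups shown, the low number belongs to tert-butyl alone. Oxan-4-yl in place of ethyl gives a 1.1-fold lower number from compound 1 to compound 4 (0.05 log units; within the scatter), so these two groups cannot be told apart here, despite the ring that oxan-4-yl brings.

Going by these compounds, the step involving the methyl group of compound 3 cannot be read: the limit of > 100000 nM in this assay, at which 1 of the 4 values shown sits. Whether the oxygen inside the oxan-4-yl ring goes with the high number stays open: a cyclohexyl group on the same ether oxygen would separate the ring from that oxygen, and a piperidin-4-yl group would show what a ring amine does there.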